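Expected Growth Inhibition for a Trifluoromethylphenyl Variant

A few compounds are considered here, and "the series" means these few. Any claim that something is new, unique, unknown or untested is made for them only; others in the source may bear on it.

Of the compounds shown here, two in this set have been measured. Compound 1 `O=S(=O)(NCCNCc1ccc(-c2ccccc2)cc1)c1cc(C(F)(F)F)cc(C(F)(F)F)c1` gives 2800 nM in a functional assay on HPAC cells (Homo sapiens) for inhibition, read by MTT assay, with a stated time of 72 h; on this read-out higher numbers stand for weaker inhibition of growth and lower numbers for stronger inhibition of growth. Compound 2 `COc1ccc(CNCCCNS(=O)(=O)c2cc(C(F)(F)F)cc(C(F)(F)F)c2)cc1OC` gives 3500 nM in this assay; this is the higher of the two numbers, but the number for compound 1 lies within the usual scatter of it, so the two cannot be told apart on this read-out.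

Compound 3 `O=S(=O)(NCCCNCc1ccc(C(F)(F)F)cc1)c1cc(C(F)(F)F)cc(C(F)(F)F)c1` has not yet been measured. It differs from compound 2 in a single place: 4-(trifluoromethyl)phenyl in place of 3,4-dimethoxyphenyl on a saturated chain carbon bound to an amine nitrogen. For the measured compounds named here, no measured pair in this set carries the same change, so there is no direct precedent for how the number will move. What the data do show is that the two measured compounds, which carry different groups at that end of the molecule, give numbers close to each other. On that basis compound 3 is expected to give about 3000 nM in this assay, with a likely range from 1200 nM to 7500 nM. The expected step of a 1.2-fold lower number from compound 2 to compound 3 (0.07 log units; within the scatter) is small, in no particular direction, and not beyond the scatter.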

Compound 3, concentration for 50% growth inhibition: 2700 nM
The estimate for compound 3 lay 1.1-fold (0.05 log units) above the measured number; low and high end bracket the measured number.
By their numbers in this assay, from the lowest: compounds 3, 1 and 2 (each within the scatter of the next).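

In this assay, for the compounds shown here, the exchange of 3,4-dimethoxyphenyl for 4-(trifluoromethyl)phenyl on a saturated chain carbon bound to an amine nitrogen gives the first step in this set that can be read at a single place (a 1.3-fold lower number from compound 2 to compound 3 (0.11 log units; within the scatter)). It shows that, between this pair, the two methoxy groups can give way to a trifluoromethyl group, and the hydrogen-bond acceptors counted on the leaving group can disappear, while the heavy-atom count stays the same and the number in this read-out cannot be told from that of compound 2. Nothing measured here accounts for this outcome, so the result stands only as an observation about this one pair.

What the compounds shown leave open is whether this place stays as undemanding with a group of another kind on the same saturated chain carbon, such as a pyridine ring or a phenyl ring carrying a carboxylic acid or an amine. On these data alone, it also remains open whether the same exchange would read alike on the chain that compound 1 carries.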